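Removing the methoxy group from the cyclohexanecarboxamide

The source may hold more compounds than are shown below. What is called first, only, known or untested is meant among the compounds shown, and "the series" means these compounds.

compound 1, `COc1ccc(-c2cnc(NC(=O)C3CCCCC3)n2C)cc1`: > 100000 nM
compound 2, `COc1ccc(-c2cnc(NC(=O)C3CCOCC3)n2C)cc1`: > 100000 nM
compound 3, `COc1ccc(-c2cnc(NC(=O)c3cnc[nH]3)n2C)cc1`: > 100000 nM

In a toxicity assay on THP-1 cells (Homo sapiens) for inhibition (a higher number here means that more compound is tolerated, a lower number that less compound is tolerated), compound 1 gives > 100000 nM, which is a limit of the assay and not a number. Compound 2 gives > 100000 nM, also a limit. Compound 3 gives > 100000 nM, again a limit. The steps a step that the two limits leave unreadable from compound 1 to compound 2, a step that the two limits leave unreadable from compound 1 to compound 3 and a step that the two limits leave unreadable from compound 2 to compound 3 therefore have no readable size, because every value sits at the limit of > 100000 nM in this assay, at which 3 of the 3 values shown sit.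

The unmeasured compound 4 `Cn1c(-c2ccccc2)cnc1NC(=O)C1CCCCC1` differs from compound 1 by hydrogen in place of methoxy on an aromatic carbon. Within the data shown here, none of the measured steps bears directly on this change: all three alter the group on the carbonyl carbon, and none was readable anyway. What the measured compounds do show is that varying the amide portion leaves every value at the limit, so no step beyond the scatter can be expected from this smaller change either. Compound 4 is expected to give about 100000 nM, within 50000 nM to 200000 nM, most likely reported again only as a limit. The expected step is a number no higher from compound 1 to compound 4 (the limit leaves the size open).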

Compound 4, half-maximal cytotoxic concentration: > 100000 nM
Compound 4 gave a limit, no number (the forecaster's own chance of this, stated with the estimate: 85%); the middle value lies on the limit itself.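

In this assay compound 4 gives > 100000 nM, a limit and not a number, so the change from compound 1 to compound 4 cannot be sized: the limit of > 100000 nM in this assay, at which 4 of the 4 values shown sit.

The compounds shown leave open what concentration of any of them is no longer tolerated, and whether hydrogen in place of methoxy alters it.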